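The source may hold more compounds than are shown below. What is called first, only, known or untested is meant among the compounds shown, and "the series" means these compounds.

Working notes on the chalcone series. Compound 1 `Cc1cc(Nc2ccc(C(=O)/C=C/c3ccc(OC(F)(F)F)cc3)cc2)n2nc(SCc3nc4ccccc4[nH]3)nc2n1` gives 220 nM in a functional assay on SW-620 cells (Homo sapiens) for cytotoxicity, read by MTT assay, with stated times of 4 h and 72 h, tested at 2 uM; on this read-out higher numbers stand for weaker inhibition and lower numbers for stronger inhibition. Two close analogues carry a different group on the same aromatic ring: compound 2 `COc1ccc(/C=C/C(=O)c2ccc(Nc3cc(C)nc4nc(SCc5nc6ccccc6[nH]5)nn34)cc2)cc1` gives 170 nM in this assay, and compound 3 `Cc1cc(Nc2ccc(C(=O)/C=C/c3ccc(Br)cc3)cc2)n2nc(SCc3nc4ccccc4[nH]3)nc2n1` gives 290 nM. On these three numbers compound 1 holds the second highest place, but the spread is small: a 1.3-fold lower number from compound 1 to compound 2 (0.11 log units; within the scatter), and a 1.3-fold higher number from compound 1 to compound 3 (0.12 log units; within the scatter). Between the other two analogues, a 1.7-fold higher number from compound 2 to compound 3 (0.23 log units; within the scatter). None of the three pairwise steps clears the scatter, so within this set the aryl substituent on the chalcone has not yet shifted the read-out in a way one can trust.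

Compound 4 `Cc1cc(Nc2ccc(C(=O)/C=C/c3cccc(Cl)c3)cc2)n2nc(SCc3nc4ccccc4[nH]3)nc2n1` has not been measured. Relative to compound 1 the change is 3-chlorophenyl in place of 4-(trifluoromethoxy)phenyl on a double-bonded chain carbon bound to a double-bonded chain carbon. The step that bears most directly on it is the exchange of the trifluoromethoxy for a halogen on that ring, seen in compound 3, which stayed within the scatter; the methoxy-to-bromo step between compound 2 and compound 3 was likewise within the scatter. Going by the values given here, a chlorine at a different position of the ring has no precedent here, so the expectation for compound 4 in this assay is a step of about a 1.1-fold higher number from compound 1 to compound 4 (0.06 log units; within the scatter), not beyond the scatter, with the number expected to land near 250 nM and most probably between 120 nM and 520 nM.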

Compound 4, half-maximal inhibitory concentration: 400 nM
Compound 4: the middle estimate sits 1.6-fold (0.20 log units) below what was measured; low and high end bracket the measured number.
By their numbers in this assay, from the lowest: compounds 2, 1, 3 and 4 (each within the scatter of the next, the first and the last beyond it).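

In this assay, going by these compounds alone, the exchange of the aryl group on a double-bonded chain carbon bound to a double-bonded chain carbon now yields the only step in this set that clears the scatter, a modest one (a 2.4-fold higher number from compound 2 to compound 4 (0.37 log units; beyond the scatter)). The other two steps with 3-chlorophenyl entering stay within the scatter (a 1.8-fold higher number from compound 1 to compound 4 (0.26 log units; within the scatter); a 1.4-fold higher number from compound 3 to compound 4 (0.14 log units; within the scatter)), so the separation holds against the 4-methoxyphenyl analogue alone. This position therefore accepts four different aryl groups with at most that modest separation at the two ends of the set, and 4-(trifluoromethoxy)phenyl and 4-bromophenyl cannot be told apart from 3-chlorophenyl on these numbers.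

Still open is whether the place of the substituent on the ring or the identity of the halogen carries any of this, since 3-chlorophenyl differs from 4-bromophenyl in both, and whether an amine or a carboxylic acid on this ring would move the read-out further than the aryl groups shown. The compounds shown come with no evidence that accounts for these steps.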